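Trimming the Sulfonyl Substituent in a Sulfonamide Series

This account rests on a few compounds, and the source may have more. Where it says the series, first, only, none or still open, it means among the compounds named here.

Compound 1 `C=Cc1ccc(S(=O)(=O)Nc2ccc3oc(-c4ccccc4)nc3c2)cc1` carries a 4-vinylphenyl group on its sulfonyl sulfur, and the shared core is joined to a sulfonamide nitrogen. In an assay on isolated protein for inhibition of malate dehydrogenase, mitochondrial (Sus scrofa), with stated times of 45 min and 30 min (on this read-out higher numbers stand for weaker inhibition and lower numbers for stronger inhibition), compound 1 gives > 63000 nM, which is a limit of the assay rather than a measured number. Two companions stand in the same place. Compound 2 `C=Cc1ccc(S(=O)(=O)Nc2ccc(-c3nc4ccccc4o3)cc2)cc1` gives > 63000 nM in this assay, again a limit. Compound 3 `O=S(=O)(Nc1ccc(-c2nc3ccccc3o2)cc1)c1ccc(F)cc1` gives > 63000 nM in this assay, also a limit. For the measured compounds named here, the single one-point change among the measured compounds, a step that the two limits leave unreadable from compound 2 to compound 3, cannot be read because both ends rest at the limit of > 63000 nM in this assay, at which 3 of the 3 values shown sit.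

Compound 4 `CS(=O)(=O)Nc1ccc2oc(-c3ccccc3)nc2c1` differs from compound 1 by methyl in place of 4-vinylphenyl on a sulfonyl sulfur. No measured step concerns the group on the sulfonyl sulfur, and the only step shown is unreadable, so nothing in the numbers points to a change in either direction. Going by the values given here, what the three values do show is that every compound so far sits at the limit of > 63000 nM in this assay, at which 3 of the 3 values shown sit, and compound 4 is expected to do the same. Compound 4 is therefore estimated at 100000 nM in this assay, within 30000 nM to 400000 nM. The step that the limit leaves unreadable from compound 1 to compound 4 that this estimate implies is expected to be nothing beyond the scatter.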

Compound 4, half-maximal inhibitory concentration: > 63000 nM
Compound 4: no number, only a limit (the forecaster's own chance of this, stated with the estimate: 85%); the middle value is on the limit's open side.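

Compound 1 and compound 4 both rest at a limit rather than a measured number, so no step between them can be read for methyl in place of 4-vinylphenyl on a sulfonyl sulfur: the limit of > 63000 nM in this assay, at which 4 of the 4 values shown sit.

The compounds shown leave open whether any group on the sulfonyl sulfur changes inhibition at all, and how strongly any of these four compounds actually inhibits.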